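A few compounds are considered here, and "the series" means these few. Any claim that something is new, unique, unknown or untested is made for them only; others in the source may bear on it.

Working notes on the series. Among the measured compounds shown here, in a functional assay for inhibition, with Rattus norvegicus as the target, at pH 7.35 (on this read-out lower numbers stand for stronger inhibition and higher numbers for weaker inhibition), compound 1 `CCOC(=O)C(=O)C(CC)NC(=O)C(CC(C)C)NC(=O)OCc1ccccc1` gives 300000 nM, the top number of the three measured so far, though not separated from compound 3 `CCCCC(NC(=O)C(CC(C)C)NC(=O)OCc1ccccc1)C(=O)C(=O)OCC`, which gives 150000 nM. The a 2.0-fold lower number from compound 1 to compound 3 (0.30 log units; within the scatter) stays within the scatter. Only compound 2 `CCOC(=O)C(=O)C(CC)NC(=O)C(CC(C)C)NC(=O)C(CC)Oc1ccccc1`, at 22000 nM, stands clearly apart.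

The change under consideration leads to compound 4 `CCCCNC(=O)C(=O)C(CC)NC(=O)C(CC(C)C)NC(=O)OCc1ccccc1`: butylamino in place of ethoxy on a carbonyl carbon, (butylamino in place of ethoxy on a carbonyl carbon).

For the measured compounds named here, no measured step touches the ethoxy group, so the evidence is indirect. The a 14-fold lower number from compound 1 to compound 2 (1.13 log units; beyond the scatter) replaces benzyloxy on a different carbonyl carbon and is large, which shows that this series can respond strongly to a single exchange on a carbonyl carbon. The a 2.0-fold lower number from compound 1 to compound 3 (0.30 log units; within the scatter) concerns the chain and says little about this position. Neither step fixes a direction for the exchange of ethoxy for butylamino. A moderate move in this assay towards a lower number is the working expectation, held loosely, and a result within the scatter of compound 1 would not surprise.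

Going by the values given here, the step expected is a 3.8-fold lower number from compound 1 to compound 4 (0.57 log units; beyond the scatter), smaller than the one seen for compound 2. For compound 4 the estimated value is 80000 nM, with an expected range of 15000 nM to 350000 nM.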

Compound 4, half-maximal inhibitory concentration: 35000 nM
For compound 4 the middle estimate is 2.3-fold (0.36 log units) above the measured one; the range from low to high includes it.
By their numbers in this assay, from the lowest: compounds 2 and 4 (each within the scatter of the next); then compounds 3 and 1 (each within the scatter of the next).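

In this assay, butylamino in place of ethoxy on a carbonyl carbon gives an 8.6-fold lower number from compound 1 to compound 4 (0.93 log units; beyond the scatter) and so lies beyond the scatter. Among the compounds shown here, this is the first direct reading at this position: the earlier steps changed other parts of the series, whereas this one shows that the ethoxy group can be exchanged here without loss on this read-out and that the exchange moves the number downwards. The exchange also replaces an oxygen-linked group with a nitrogen-linked one that carries a hydrogen-bond donor and has a longer chain, but the data at hand give no measured reason for the shift.

For the compounds shown here, the single step does not separate the change of linking atom from the change of chain, and ethylamino or butoxy on the same carbonyl carbon would tell these two apart. Also open, going by these compounds, is whether butylamino has a similar effect alongside the 1-phenoxypropyl group of compound 2 or the longer chain of compound 3, and whether a longer chain such as hexylamino or a cyclic amine such as piperidine would extend the trend.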